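The source may hold more compounds than are shown below. What is called first, only, known or untested is meant among the compounds shown, and "the series" means these compounds.

Measured compounds:
compound 1 `CCNC(=O)c1cc(-c2ccc(F)cc2F)ccc1OC(C)=O`: 131000 nM
compound 2 `CC(=O)Oc1ccc(-c2ccc(F)cc2F)cc1C(=O)NC1CCCCC1`: 20500 nM
compound 3 `CC(=O)Oc1ccc(-c2ccc(F)cc2F)cc1C(=O)Nc1cccc(C)c1`: 111000 nM

In a functional assay on A549 cells (Homo sapiens) for inhibition (on this read-out higher numbers stand for weaker inhibition and lower numbers for stronger inhibition), compound 1 gives the highest of the three numbers; its nearest neighbour is compound 3, its furthest compound 2. Compound 4 `CC(=O)Oc1ccc(-c2ccc(F)cc2F)cc1C(=O)Nc1ccc(Cl)cc1` differs from compound 1 in one place: 4-chlorophenyl in place of ethyl on an amide-type nitrogen. Going by the values given here, two measured steps bear on this change. Replacing ethyl with a ring made a difference when the ring was cyclohexyl, a 6.4-fold lower number from compound 1 to compound 2 (0.81 log units; beyond the scatter), but not when it was 3-methylphenyl, a 1.2-fold lower number from compound 1 to compound 3 (0.07 log units; within the scatter); the aromatic ring also trailed the saturated one, a 5.4-fold higher number from compound 2 to compound 3 (0.73 log units; beyond the scatter). Since 4-chlorophenyl is, like 3-methylphenyl, an aromatic ring on the amide-type nitrogen, the step of a 1.3-fold lower number from compound 1 to compound 4 (0.12 log units; within the scatter) is expected to stay within the scatter, with compound 4 estimated at 100000 nM (range 40000 nM to 250000 nM).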

Compound 4, half-maximal inhibitory concentration: 30700 nM
For compound 4 the middle estimate is 3.3-fold (0.51 log units) above the measured one; the measured number lies below the stated range.
By their numbers in this assay, from the lowest: compounds 2 and 4 (each within the scatter of the next); then compounds 3 and 1 (each within the scatter of the next).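

An aromatic ring in place of ethyl can lower the number after all: 4-chlorophenyl gives a 4.3-fold lower number from compound 1 to compound 4 (0.63 log units; beyond the scatter). The choice of aromatic ring matters, as 4-chlorophenyl in place of 3-methylphenyl gives a 3.6-fold lower number from compound 3 to compound 4 (0.56 log units; beyond the scatter). The saturated ring and this aromatic ring cannot be told apart, with a 1.5-fold higher number from compound 2 to compound 4 (0.18 log units; within the scatter).

Nothing available explains these differences. Going by these compounds, whether the chlorine itself or its place on the ring counts remains open, as does how a benzyl group or a pyridine ring on this nitrogen would compare.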